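The source may report more compounds than this note shows. Statements on the series, on what has been measured and on what is new or still open speak of the compounds shown alone.

In a functional assay on DU-145 cells (Homo sapiens) for antiproliferative activity, read by propidium iodide staining, with a stated time of 96 h (on this read-out lower numbers stand for stronger inhibition and higher numbers for weaker inhibition), three compounds have been measured so far:

compound 1, `CC(O)(COc1cccc(C(F)(F)F)c1)C(=O)Nc1ccc(S(F)(F)(F)(F)F)cc1`, gives 21900 nM;
compound 2, `CC(O)(COc1cc(C(F)(F)F)cc(C(F)(F)F)c1)C(=O)Nc1ccc(S(F)(F)(F)(F)F)cc1`, gives 8600 nM;
compound 3, `CC(O)(CS(=O)(=O)c1cccc(C(F)(F)F)c1)C(=O)Nc1cccc(S(F)(F)(F)(F)F)c1`, gives 37300 nM.

Compounds 1 and 2 share one core and differ in a single place, (trifluoromethyl in place of hydrogen on an aromatic carbon). That change produced a 2.5-fold lower number from compound 1 to compound 2 (0.41 log units; beyond the scatter). Compound 3 carries a different core; how it differs from compound 1 is not broken down here. Its number is within the scatter of that of compound 1, and only the gap to compound 2 lies beyond the scatter.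

Compound 4, `CC(O)(CS(=O)(=O)c1cc(C(F)(F)F)cc(C(F)(F)F)c1)C(=O)Nc1cccc(S(F)(F)(F)(F)F)c1`, is the counterpart of compound 3 in the same sense: it differs from compound 3 in one place, (trifluoromethyl in place of hydrogen on an aromatic carbon), and the surroundings of that place read exactly as they do for the change from compound 1 to compound 2, so the change is the same. For the measured compounds named here, on the strength of the one measured instance of it, a 2.5-fold lower number from compound 1 to compound 2 (0.41 log units; beyond the scatter), a step of similar size is expected for compound 4 in this assay, namely a 2.5-fold lower number from compound 3 to compound 4 (0.40 log units; beyond the scatter). Compound 4 is therefore estimated at 15000 nM, most likely between 7000 nM and 35000 nM.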

Compound 4, half-maximal inhibitory concentration: 13700 nM
For compound 4 the middle estimate is 1.1-fold (0.04 log units) above the measured one; measured number inside the range.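

In this assay, trifluoromethyl in place of hydrogen on an aromatic carbon gave a 2.7-fold lower number from compound 3 to compound 4 (0.43 log units; beyond the scatter). Set beside the earlier instance, the two steps agree, so in this series the change carried over from the core of compound 1 to the core of compound 3 with its size intact: the same change on two cores in this assay, a 2.5-fold lower number (0.41 log units; beyond the scatter) from compound 1 to compound 2 and a 2.7-fold lower number (0.43 log units; beyond the scatter) from compound 3 to compound 4, 1.1-fold (0.03 log units) apart, within the scatter of two such steps. This agreement rests on just two pairs, with the change made at the same kind of place in both, so it says nothing about other cores and does not explain why the step has this size.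

The compounds shown leave open whether another group at that place, such as chlorine, a nitrile or a methoxy group, would give a step of similar size. They also leave open whether the same step would hold on a core in which an amine or a carboxylic acid stands on that ring.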